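This account rests on a few compounds, and the source may have more. Where it says the series, first, only, none or still open, it means among the compounds named here.

Working notes on the series. Of the compounds shown here, two have been measured so far, compound 1 (`Cc1ccc(S(=O)(=O)N/N=C2\C(=O)Nc3ccc(S(=O)(=O)N4CCOCC4)cc32)cc1`) and compound 2 (`N/N=C1\C(=O)Nc2ccc(S(=O)(=O)N3CCOCC3)cc21`). In a functional assay on MCF7 cells (Homo sapiens) for cytotoxicity, read by sulforhodamine B assay, with a stated time of 24 h (a higher number here means a weaker inhibitor, a lower number a stronger inhibitor), compound 1 gives 38400 nM and compound 2 gives 46800 nM. Going by the values given here, compound 2 thus stands within the scatter of the only other measured value, and the step that replaces (4-methylphenyl)sulfonyl with hydrogen on an amine nitrogen reads a 1.2-fold higher number from compound 1 to compound 2 (0.09 log units; within the scatter).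

The next entry is compound 3 (`O=C1Nc2ccc(S(=O)(=O)N3CCOCC3)cc2/C1=N/Nc1ccccc1`), with this change: phenyl in place of hydrogen on an amine nitrogen. Phenyl takes the place of hydrogen on that same amine nitrogen. Among the compounds with values here, the one measured step at this place bears on the change, but it is thin evidence, and no measured compound carries phenyl there. No step beyond the scatter is expected in this assay because a 1.2-fold higher number from compound 1 to compound 2 (0.09 log units; within the scatter) stayed inside it. The estimated step is a 1.2-fold lower number from compound 2 to compound 3 (0.09 log units; within the scatter), with no clear direction expected. The range is kept wide since it rests on a single step. For compound 3 the expected value is 38000 nM, with an estimated range of 14000 nM to 90000 nM.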

Compound 3, half-maximal inhibitory concentration: 30300 nM
For compound 3 the middle estimate is 1.3-fold (0.10 log units) above the measured one; the measured number falls inside the stated range.
By their numbers in this assay, from the lowest: compounds 3, 1 and 2 (each within the scatter of the next).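

In this assay the entry of phenyl reads a 1.5-fold lower number from compound 2 to compound 3 (0.19 log units; within the scatter) and the exchange of (4-methylphenyl)sulfonyl for phenyl reads a 1.3-fold lower number from compound 1 to compound 3 (0.10 log units; within the scatter) on the same amine nitrogen. Hydrogen, (4-methylphenyl)sulfonyl and phenyl at this place now all stand within the scatter of one another, so the flat reading no longer rests on a single step, and it holds for a phenyl ring set directly on the nitrogen as well as for the sulfonyl group. Nothing at hand offers an explanation for this flat reading.

The compounds shown leave open whether a longer chain, a simple amine or a phenyl carrying a carboxylic acid on this amine nitrogen would give a step beyond the scatter. They also leave open whether the number responds at all to a change elsewhere on the shared core, which stays the same in all three compounds.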